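Branched Carbamate Variant of a Trimethoxybenzoyl Piperazine Antagonist

This account rests on a few compounds, and the source may have more. Where it says the series, first, only, none or still open, it means among the compounds named here.

Compound 1 `CCCCCCCCCC(=O)OCC1CN(C(=O)c2cc(OC)c(OC)c(OC)c2)CCN1C(=O)c1cc(OC)c(OC)c(OC)c1` gives 2820 nM in a functional assay (Oryctolagus cuniculus) for inhibition of platelet-activating factor receptor (Cavia porcellus); on this read-out higher numbers stand for weaker inhibition and lower numbers for stronger inhibition. Compound 2 `CCC(CC)C(=O)OCC1CN(Cc2cc(OC)c(OC)c(OC)c2)CCN1Cc1cc(OC)c(OC)c(OC)c1` gives 2700 nM in this assay. Compound 3 `CCCCNC(=O)OCC1CN(C(=O)c2cc(OC)c(OC)c(OC)c2)CCN1C(=O)c1cc(OC)c(OC)c(OC)c1` gives 240 nM in this assay.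

Compound 3 holds the lowest number of the three: compound 1 sits above it by a 12-fold lower number from compound 1 to compound 3 (1.07 log units; beyond the scatter), and compound 2 stands at a similar height. Compound 4 `CCC(CC)NC(=O)OCC1CN(C(=O)c2cc(OC)c(OC)c(OC)c2)CCN1C(=O)c1cc(OC)c(OC)c(OC)c1` differs from compound 3 by pentan-3-yl in place of butyl on an amide-type nitrogen. Among the measured compounds shown here, no measured step bears on this change: the one step recorded, from compound 1 to compound 3, swaps the carbonyl substituent rather than reshaping the alkyl group on the nitrogen. Compound 4 is therefore expected to land close to compound 3, with a step of a 1.3-fold higher number from compound 3 to compound 4 (0.10 log units; within the scatter) not beyond the scatter. The estimate for compound 4 is 300 nM, within 100 nM to 900 nM.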

Compound 4, half-maximal inhibitory concentration: 130 nM
The estimate for compound 4 lay 2.3-fold (0.36 log units) above the measured number; measured number inside the range.
By their numbers in this assay, from the lowest: compounds 4 and 3 (each within the scatter of the next); then compounds 2 and 1 (each within the scatter of the next).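

On the amide-type nitrogen, pentan-3-yl in place of butyl gives no change beyond the scatter (a 1.8-fold lower number from compound 3 to compound 4 (0.27 log units; within the scatter)), so this position accepts a branched group as well as a straight one in this assay. The large gain over the nonyl ester also persists with the branched group (a 22-fold lower number from compound 1 to compound 4 (1.34 log units; beyond the scatter)). Nothing available explains why these numbers fall where they do.

The compounds shown leave open whether a cyclohexyl group or a longer chain such as octyl on this nitrogen would keep the number in this assay near those of compound 3 and compound 4.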